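Trimming sec-butyl to isopropyl on compound 2

The compounds below may be only part of what the source reports. "The series", "measured", "known", "first", "only" and "open" are said of these compounds alone.

Measured so far in an ADME assay on the whole organism for inhibition, with Echinochloa crus-galli var. formosensis as the target, with a stated time of 4 days; a lower number here means a stronger inhibitor, a higher number a weaker inhibitor:
Compound 1 (`CC[C@H](C)Nc1nc(Cl)nc(N[C@@H](C)c2ccccc2)n1`) gives 14100 nM
Compound 2 (`CC[C@H](C)Nc1nc(Cl)nc(N[C@H](C)c2ccccc2)n1`) gives 52500 nM

For the measured compounds named here, compound 2 holds the higher number of the pair, and its only neighbour, compound 1, stands at 14100 nM on the stronger side. Going by the values given here, the one measured step, a 3.7-fold higher number from compound 1 to compound 2 (0.57 log units; beyond the scatter), is modest and comes with the fact that compounds 1 and 2 differ only in the configuration as drawn as its only distinction.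

Compound 3 (`CC(C)Nc1nc(Cl)nc(N[C@H](C)c2ccccc2)n1`) takes the sec-butyl group of compound 2 to isopropyl, and the change reads hydrogen in place of methyl on a saturated chain carbon, two bonds along the chain from a nitrogen on an aromatic ring in full. Among the compounds with values here, no measured step touches this place. Compound 1 and compound 2 both carry sec-butyl, so a 3.7-fold higher number from compound 1 to compound 2 (0.57 log units; beyond the scatter) shows only how large a modest change in this assay can be and gives no direction here. Compound 3 keeps the drawn configuration of compound 2 at the stereocentre behind that step.

No shift beyond the scatter is therefore expected, and the estimated 1.1-fold lower number from compound 2 to compound 3 (0.02 log units; within the scatter) is small, with either direction open. The estimate for compound 3 is 50000 nM, with an expected range from 17000 nM to 150000 nM.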

Compound 3, half-maximal inhibitory concentration: 2000 nM
Estimate against measurement, compound 3: 25-fold (1.40 log units) above; measured number outside the range, below it.
By their numbers in this assay, from the lowest: compound 3; then compound 1; then compound 2.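

In this assay, for the compounds shown here, the sec-butyl group of compound 2 turns out to be a sensitive place, with a 26-fold lower number from compound 2 to compound 3 (1.42 log units; beyond the scatter) set against the modest 3.7-fold higher number from compound 1 to compound 2 (0.57 log units; beyond the scatter) that was the only step read before. Hydrogen in place of methyl on a saturated chain carbon, two bonds along the chain from a nitrogen on an aromatic ring, is a loss of one heavy atom, and in this pair that small edit moves the number towards the stronger side by a large step, while the configuration at the stereocentre kept from compound 2 stays as drawn. Nothing available accounts for the size or the direction of this step.

The compounds shown leave open whether trimming to isopropyl gives a step of similar size when the stereocentre carries the configuration drawn in compound 1. They also leave open how the number runs along this chain, whether an ethyl or methyl group on the same nitrogen goes further in the same direction, and whether a cyclopropyl group or a longer chain such as n-butyl reverses it.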